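The compounds below may be only part of what the source reports. "The series", "measured", "known", "first", "only" and "open" are said of these compounds alone.

Measured compounds:
compound 1 `N#C[Se]c1ccc(NC(=O)OCc2ccc([N+](=O)[O-])cc2)cc1` in a functional assay on MCF7 cells (Homo sapiens) for cytotoxicity, read by MTT assay, with a stated time of 72 h; a higher number here means a weaker inhibitor of growth, a lower number a stronger inhibitor of growth: 11800 nM
compound 2 `N#C[Se]c1ccc(NC(=O)Oc2ccc(F)cc2)cc1`: 8300 nM
compound 3 `C=CCOC(=O)Nc1ccc([Se]C#N)cc1`: 15000 nM

Compound 3 carries the highest of the three numbers, but its distance to compound 1 and to compound 2 stays within the scatter of repeated measurements, so no ordering among the three can be claimed from these values.

Compound 4 `N#C[Se]c1ccc(NC(=O)OCc2ccccc2)cc1` has not yet been measured. It differs from compound 3 in one place: phenyl in place of vinyl on a saturated chain carbon bound to an oxygen next to a carbonyl group. Going by the values given here, no measured pair shows this change directly. Compound 1, which also carries a benzyl-type carbamate, gives 11800 nM in this assay, a number close to that of compound 3, which suggests that the new aromatic ring by itself does not move the number far.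

The step from compound 3 to compound 4 is expected to be a 1.4-fold lower number from compound 3 to compound 4 (0.13 log units; within the scatter), a shift that need not exceed the scatter. Compound 4 is therefore expected to give about 11000 nM, within a range from 5000 nM to 25000 nM.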

Compound 4, concentration for 50% growth inhibition: 8700 nM
The estimate for compound 4 lay 1.3-fold (0.10 log units) above the measured number; the range from low to high includes it.
By their numbers in this assay, from the lowest: compounds 2, 4, 1 and 3 (each within the scatter of the next).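

In this assay, the step of phenyl in place of vinyl on a saturated chain carbon bound to an oxygen next to a carbonyl group gives a 1.7-fold lower number from compound 3 to compound 4 (0.24 log units; within the scatter), and the step of hydrogen in place of nitro on an aromatic carbon gives a 1.4-fold lower number from compound 1 to compound 4 (0.13 log units; within the scatter). These are the first single-place comparisons in the series, and neither change carries the number beyond the scatter, so neither the phenyl nor the nitro group is shown to matter in this assay. No measurement is at hand that would explain these numbers.

Going by these compounds, it remains open whether a carboxylic acid or a longer chain in place of vinyl would move the number beyond the scatter. The same holds for an amine or a methoxy group in place of nitro on an aromatic carbon.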